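Swapping Nitro for Carboxy on a Shared Core

A few compounds are considered here, and "the series" means these few. Any claim that something is new, unique, unknown or untested is made for them only; others in the source may bear on it.

Values measured so far in a physicochemical assay for acid dissociation, are these
- compound 1 `NS(=O)(=O)c1ccc(S(=O)(=O)CCCO)cc1` gives 8.98
- compound 2 `NS(=O)(=O)c1ccc(S(=O)(=O)CCCO)c([N+](=O)[O-])c1` gives 8

Going by the values given here, of these two numbers, the one for compound 2 is the lower. Compound 3 `NS(=O)(=O)c1ccc(S(=O)(=O)CCCO)c(C(=O)O)c1` differs from compound 2 by carboxy in place of nitro on an aromatic carbon with carboxy in place of nitro on an aromatic carbon. Among the compounds with values here, the one measured step bearing on this is a number 0.98 log units lower from compound 1 to compound 2 (beyond the scatter) which is modest and brought in the nitro group that now leaves. Within the data shown here, no compound with carboxy has been measured, so only part of that step is expected to be reversed. The estimated change in this assay is a number 0.60 log units higher from compound 2 to compound 3 (beyond the scatter) as a rise smaller than that measured step. For compound 3 the estimate is 8.6 within a range from 7.7 to 9.4 as an expected value.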

Compound 3, acid dissociation constant: 9.28
Compound 3: the middle estimate sits 0.68 log units below what was measured; measured number inside the range.
By their numbers in this assay, from the lowest: compound 2; then compounds 1 and 3 (each within the scatter of the next).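

In this assay, the swap on this aromatic carbon gives a number 1.28 log units higher from compound 2 to compound 3 (beyond the scatter), a large step that takes away the whole of the drop that came with nitro. Carboxy in place of hydrogen at the same place gives a number 0.30 log units higher from compound 1 to compound 3 (within the scatter), so these two compounds cannot be told apart here, and the drop seen with nitro does not appear with every group placed there. Nothing available explains why nitro and carboxy differ at this position.

Going by these compounds, whether an amine or a methyl ester on this aromatic carbon would give a number like that of compound 3 or like that of compound 2 stays open.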